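This account rests on a few compounds, and the source may have more. Where it says the series, first, only, none or still open, it means among the compounds named here.

Measured in a functional assay on NCI-H460 cells (Homo sapiens) for inhibition, read by sulforhodamine B assay, with a stated time of 48 h; a higher number here means a weaker inhibitor of growth, a lower number a stronger inhibitor of growth:

- compound 1 `CCOC(=O)C1=C(C)NC(=O)NC1c1ccc(SC)cc1`: 3.6 ug/mL
- compound 2 `CCOC(=O)C1=C(C)NC(=S)NC1c1cccc(OC)c1`: 29.2 ug/mL
- compound 3 `CCOC(=O)C1=C(C)NC(=O)NC1C1CCCCC1`: > 250 ug/mL (a limit of the assay, not a number)

Of the two numeric results, compound 1 has the lower, at 3.6 ug/mL. The number for compound 2 is higher, at 29.2 ug/mL, and the gap between them lies beyond the scatter. Compound 3 has no number to place beside them, only its limit.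

The next compound to be tested is compound 4 `CCOC(=O)C1=C(C)NC(=O)NC1c1ccc(O)cc1`, which keeps the core of compound 1 and changes one group. The change is hydroxy in place of methylsulfanyl on an aromatic carbon, para to a large group. Going by the values given here, no measured pair in this small set tests that exchange, so any forecast is loose. A higher number in this assay is the more likely outcome, since compound 1 starts from the lowest number, 3.6 ug/mL, while compound 2 reaches 29.2 ug/mL. The expected change is a 5.6-fold higher number from compound 1 to compound 4 (0.74 log units; beyond the scatter), a move towards weaker inhibition of growth that would probably lie beyond the scatter. Compound 4 is estimated at 20 ug/mL, with an expected range of 5 ug/mL to 100 ug/mL.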

Compound 4, concentration for 50% growth inhibition: 40.6 ug/mL
The estimate for compound 4 lay 2.0-fold (0.31 log units) below the measured number, within the range that was stated.
By their numbers in this assay, from the lowest: compound 1; then compounds 2 and 4 (each within the scatter of the next). At a limit, above all of these: compound 3.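

Going by these compounds alone, on the aromatic carbon para to a large group, putting hydroxy in place of methylsulfanyl gives an 11-fold higher number from compound 1 to compound 4 (1.05 log units; beyond the scatter) in this assay and provides the first comparison in this set that can be read across a single change. With the rest of compound 1 held fixed, the group at this one place is enough to move the number beyond the scatter, so the position is not indifferent to what it carries, and of these two groups methylsulfanyl goes with the stronger inhibition of growth. Nothing measured here accounts for the size of this step.

The compounds shown leave open where an amine, a carboxylic acid or a longer sulfur-linked chain at this place would fall, and so whether the low number of compound 1 is particular to methylsulfanyl or shared by other groups. Also open, from the compounds shown here alone, is what the carbonyl of the core contributes, since compound 2 carries a thiocarbonyl there but differs from compound 1 and compound 4 in more than one place.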